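The source may report more compounds than this note shows. Statements on the series, on what has been measured and on what is new or still open speak of the compounds shown alone.

Compound 1, with the structure `COc1ccc(-c2ocnc2-c2cc(Br)c(OC)c(OC)c2)cc1OC`, was tested in a functional assay on HeLa cells (Homo sapiens) for cytotoxicity, read by MTT assay, with a stated time of 48 h (a higher number here means a weaker inhibitor, a lower number a stronger inhibitor), and gave 70 nM. For the measured compounds named here, of the two numbers known in this assay it is the lowest. Compound 3, with the structure `COc1cc(-c2ncoc2-c2ccccc2SC)cc(OC)c1OC`, gives 7330 nM in this assay, a value that lies well beyond the usual scatter of repeated measurements. Compound 2, with the structure `COc1cc(-c2ncoc2-c2cc(Br)c(SC)c(OC)c2)cc(OC)c1OC`, reaches only a limit of the assay at > 20000 nM, so for it no number is known; the limit is described in the limit of > 20000 nM in this assay, at which 1 of the 3 values shown sits.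

Compound 4, with the structure `COc1ccc(-c2ocnc2-c2cc(Br)c(OC)c(OC)c2)cc1SC`, has not yet been measured. It differs from compound 1 in one place: methylsulfanyl in place of methoxy on an aromatic carbon. The change sits on an aromatic carbon of a six-membered aromatic ring of carbon only, ortho to a methoxy group and meta to a large group.

Going by the values given here, no step between measured compounds shows what this exchange does. Compounds 2 and 3 differ from compound 1 in more than one place. Both compounds carrying methylsulfanyl are weak, yet that is not a clean comparison. Compound 4 is therefore expected to fall off somewhat, with the step of a 4.3-fold higher number from compound 1 to compound 4 (0.63 log units; beyond the scatter) estimated to be modest rather than large. The expected value for compound 4 in this assay is 300 nM, within a range from 50 nM to 3000 nM.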

Compound 4, half-maximal inhibitory concentration: 630 nM
Beside the measured number, compound 4's estimate is 2.1-fold (0.32 log units) below it; the range from low to high includes it.
By their numbers in this assay, from the lowest: compound 1; then compound 4; then compound 3. At a limit, above all of these: compound 2.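

In this assay, for the compounds shown here, putting methylsulfanyl in place of methoxy at this position gives a 9.0-fold higher number from compound 1 to compound 4 (0.95 log units; beyond the scatter), the first reading of this exchange with nothing else in the structure changed. The two earlier compounds that carry methylsulfanyl differ from compound 1 in more than one place, so their weak results could not be assigned to this group alone, whereas here the loss belongs to this single exchange, and compound 4 still gives a measured number of 630 nM rather than a limit of the assay. Nothing in the data at hand explains why the step has this size.

The compounds shown carry only methoxy or methylsulfanyl at this position, so it stays open how a hydroxyl group, an amine or a longer chain such as ethoxy would fare there. Also open, as far as these compounds go, is whether methylsulfanyl in place of one of the other methoxy groups of compound 1 would bring a step of similar size, as a single pair of compounds speaks for one position only.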